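This account rests on a few compounds, and the source may have more. Where it says the series, first, only, none or still open, it means among the compounds named here.

Of the compounds shown here, three sharing one core have been measured in a functional assay for inhibition of sodium/hydrogen exchanger (Oryctolagus cuniculus); a higher number here means a weaker inhibitor, a lower number a stronger inhibitor. Compound 1 `Cc1cc(F)c(S(C)(=O)=O)cc1C(=O)N=C(N)N` gives 44 nM. Compound 2 `CCCCCc1cc(C)c(C(=O)N=C(N)N)cc1S(C)(=O)=O` gives 27 nM; it carries pentyl in place of fluoro on an aromatic carbon, and the step is a 1.6-fold lower number from compound 1 to compound 2 (0.21 log units; within the scatter). Compound 3 `Cc1cc(SC(C)C)c(S(C)(=O)=O)cc1C(=O)N=C(N)N` carries isopropylsulfanyl at that aromatic carbon and gives 12 nM. Compound 3 has the lowest number of the three: a 3.7-fold lower number from compound 1 to compound 3 (0.56 log units; beyond the scatter) and a 2.3-fold lower number from compound 2 to compound 3 (0.35 log units; beyond the scatter), both beyond the scatter.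

Compound 4 `Cc1cc(Sc2ccccc2Cl)c(S(C)(=O)=O)cc1C(=O)N=C(N)N` has not yet been measured. It differs from compound 3 by 2-chlorophenyl in place of isopropyl on a sulfur. For the measured compounds named here, none of the measured steps changes a group on that sulfur; the measured steps only exchanged the whole substituent on the aromatic carbon, with modest gains for the larger groups. Whether 2-chlorophenyl on sulfur behaves like isopropyl is not told by these data. For compound 4 the expected step is a 1.2-fold lower number from compound 3 to compound 4 (0.08 log units; within the scatter), within the scatter. Compound 4 is therefore estimated to give 10 nM, with a range from 3 nM to 35 nM.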

Compound 4, half-maximal inhibitory concentration: 14 nM
Estimate against measurement, compound 4: 1.4-fold (0.15 log units) below; low and high end bracket the measured number.
By their numbers in this assay, from the lowest: compounds 3, 4, 2 and 1 (each within the scatter of the next, the first and the last beyond it).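

Swapping isopropyl for 2-chlorophenyl on this sulfur, which brings in an aromatic ring and more heavy atoms, leaves the number in this assay unchanged within the scatter (a 1.2-fold higher number from compound 3 to compound 4 (0.07 log units; within the scatter)). The whole (2-chlorophenyl)sulfanyl group cannot be told apart from pentyl on the aromatic carbon (a 1.9-fold lower number from compound 2 to compound 4 (0.29 log units; within the scatter)), yet it keeps a modest gain over fluoro (a 3.1-fold lower number from compound 1 to compound 4 (0.50 log units; beyond the scatter)). No measurement at hand explains why two such different groups on sulfur read alike.

The compounds shown leave open whether the chlorine matters, since plain phenyl on the sulfur does not appear among them. They also do not tell how the number would respond to an amine or a carboxylic acid on the sulfur substituent, or to oxygen in place of the sulfur.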